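Moving the bromine on the triazole aryl ring

This account rests on a few compounds, and the source may have more. Where it says the series, first, only, none or still open, it means among the compounds named here.

Measured compounds:
compound 1 `N#CC1=C(N)Oc2c(c3nc4ccccc4nc3c3ccccc23)C12C(=O)N(Cc1cnnn1-c1ccc(Cl)cc1)c1ccccc12` gives > 50000 nM in an ADME assay on HUVEC cells (Homo sapiens) for antiproliferative activity, read by MTT assay, with a stated time of 48 h (a higher number here means a weaker inhibitor, a lower number a stronger inhibitor), a limit of the assay rather than a number.
compound 2 `N#CC1=C(N)Oc2c(c3nc4ccccc4nc3c3ccccc23)C12C(=O)N(Cc1cnnn1-c1ccc(Br)cc1)c1ccccc12` gives > 50000 nM in this assay, again a limit and not a number.

Compound 2 therefore stands at the limit; nothing finer than that is known for it. Among the compounds with values here, the only measured step, a step that the two limits leave unreadable from compound 1 to compound 2, cannot be read because the limit of > 50000 nM in this assay, at which 2 of the 2 values shown sit, holds both compounds at the same limit.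

Compound 3 `N#CC1=C(N)Oc2c(c3nc4ccccc4nc3c3ccccc23)C12C(=O)N(Cc1cnnn1-c1ccccc1Br)c1ccccc12` differs from compound 2 by 2-bromophenyl in place of 4-bromophenyl on an aromatic nitrogen. Within the data shown here, no measured step bears on this change, and the one step that exists is unreadable, so there is no basis for expecting compound 3 to move away from the limit at which compound 2 sits. Compound 3 is estimated at 60000 nM, with a range from 25000 nM to 200000 nM. The expected step is a step that the limit leaves unreadable from compound 2 to compound 3, most likely reported only as a limit.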

Compound 3, half-maximal inhibitory concentration: > 50000 nM
Compound 3 ended at the assay's limit; the forecaster's own chance of this, stated with the estimate: 85%; the middle value does not contradict the limit.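

In this assay compound 3 gives > 50000 nM, again a limit and not a number. Its steps from compound 1 and compound 2 therefore cannot be read: the limit of > 50000 nM in this assay, at which 3 of the 3 values shown sit.

The compounds shown leave open whether moving the bromine changes the activity at all, and whether any aryl group at this place gives a value inside the range of the assay.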